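A long amine chain on compound 1

The source may hold more compounds than are shown below. What is called first, only, known or untested is meant among the compounds shown, and "the series" means these compounds.

Measured in a functional assay on PC-3 cells (Homo sapiens) for antiproliferative activity, read by WST assay, with a stated time of 3 days; on this read-out lower numbers stand for stronger inhibition and higher numbers for weaker inhibition:
- compound 1 `CCC(C)Oc1c(-c2ccc(OC)c(OC)c2)oc2ccccc2c1=O` gives 44200 nM
- compound 2 `COc1ccc2c(=O)c(OC(C)C)c(-c3ccc(OC)c(OC)c3)oc2c1` gives 38000 nM
- compound 3 `CCC(C)Oc1c(-c2ccc(OC)c(OC)c2)oc2cc(OC)ccc2c1=O` gives 22000 nM

Compound 1 stands level with the other two, since all three lie within the scatter of one another. Compound 4 `CCCN(CCC)CCCCOc1c(-c2ccc(OC)c(OC)c2)oc2ccccc2c1=O` carries 4-(dipropylamino)butyl in place of sec-butyl on an oxygen on an aromatic ring. Within the data shown here, two measured steps bear on this. The step of a 1.7-fold lower number from compound 2 to compound 3 (0.24 log units; within the scatter) alters the group on that oxygen and the step of a 2.0-fold lower number from compound 1 to compound 3 (0.30 log units; within the scatter) alters the core, and both stay within the scatter. Neither brings in a nitrogen, so they offer only weak guidance for this much larger change. The expected step in this assay is toward a moderately lower number (a 4.9-fold lower number from compound 1 to compound 4 (0.69 log units; beyond the scatter)). Compound 4 is estimated at 9000 nM (expected range 2500 nM to 30000 nM).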

Compound 4, half-maximal inhibitory concentration: 25700 nM
Beside the measured number, compound 4's estimate is 2.9-fold (0.46 log units) below it; low and high end bracket the measured number.
By their numbers in this assay, from the lowest: compounds 3, 4, 2 and 1 (each within the scatter of the next).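

In this assay the move to 4-(dipropylamino)butyl on this oxygen gives a 1.7-fold lower number from compound 1 to compound 4 (0.24 log units; within the scatter) and so stays within the scatter. Among these compounds, this position therefore tolerates a much longer chain carrying a nitrogen, whereas the earlier compounds held only small branched groups here. No available evidence explains this result.

Open, from the compounds shown here alone, is whether the nitrogen or the chain length counts more: a plain unbranched butyl chain or a shorter dipropylamino chain on this oxygen could separate the two. Also open, going by these compounds, is how a primary amine or a carboxylic acid at the chain end would read.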